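Dimethoxyphenyl Ketone in Place of a Pyridyl Ketone

The source may hold more compounds than are shown below. What is called first, only, known or untested is meant among the compounds shown, and "the series" means these compounds.

Two chalcone-like compounds sharing one core have been measured. Compound 1 `COc1ccc(C(=O)/C=C/c2cn(-c3ccccc3)nc2-c2ccsc2)cc1OC` carries a dimethoxyphenyl ketone; in a functional assay on HCT-116 cells (Homo sapiens) for inhibition, read by sulforhodamine B assay, with a stated time of 72 h (a higher number here means a weaker inhibitor, a lower number a stronger inhibitor), compound 1 gives 1600 nM. Compound 2 `O=C(/C=C/c1cn(-c2ccccc2)nc1-c1cccnc1)c1ccccn1` carries a pyridin-2-yl ketone; in this assay compound 2 gives 2100 nM. The numbers of compound 2 and compound 1 lie within the scatter of each other, so no order between them can be read from these two values. Compound 3 `COc1ccc(C(=O)/C=C/c2cn(-c3ccccc3)nc2-c2cccnc2)c(OC)c1` differs from compound 2 in one place: 2,4-dimethoxyphenyl in place of pyridin-2-yl on a carbonyl carbon. Within the data shown here, no measured pair shows this exact change, so the direction of its effect is not known; given that compound 1 gives 1600 nM with a dimethoxyphenyl ketone, no step beyond the scatter is expected. The step from compound 2 to compound 3 is expected to be a 1.2-fold lower number from compound 2 to compound 3 (0.07 log units; within the scatter). Compound 3 is therefore estimated at 1800 nM, within a range from 700 nM to 4500 nM.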

Compound 3, half-maximal inhibitory concentration: 1300 nM
Beside the measured number, compound 3's estimate is 1.4-fold (0.14 log units) above it; the measured number falls inside the stated range.
By their numbers in this assay, from the lowest: compounds 3, 1 and 2 (each within the scatter of the next).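

Placing 2,4-dimethoxyphenyl in place of pyridin-2-yl on a carbonyl carbon gives the first direct reading at this position: in this assay the change is a 1.6-fold lower number from compound 2 to compound 3 (0.21 log units; within the scatter). The group on this carbonyl carbon can therefore go from a six-membered aromatic ring with a hetero atom to a larger group with a ring of carbon only, without a step beyond the scatter. No measured property bearing on this result is available.

The compounds shown leave open whether any group on this carbonyl carbon moves the number beyond the scatter. An unsubstituted phenyl, or a phenyl carrying an amine or a carboxylic acid, would test how far this tolerance of change extends.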